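The source may hold more compounds than are shown below. What is called first, only, known or untested is meant among the compounds shown, and "the series" means these compounds.

Of the compounds shown here, three built on one shared core have been tested in a functional assay on OVCAR-3 cells (Homo sapiens) for antiproliferative activity, read by spectrophotometry, with a stated time of 2 days; on this read-out lower numbers stand for stronger inhibition of growth and higher numbers for weaker inhibition of growth. Compound 1 `COc1cc(N2CCN(C(C)=O)CC2)ccc1Nc1ncc(C(F)(F)F)c(N2Cc3cccc(N(C)S(C)(=O)=O)c3C2)n1` gives 1600 nM in this assay. Compound 2 `CN(c1cccc2c1CN(c1nc(Nc3ccc(Nc4ccccc4)cc3)ncc1C(F)(F)F)C2)S(C)(=O)=O` returns only a limit of the assay in this assay, > 50000 nM, which is the limit of > 50000 nM in this assay, at which 1 of the 3 values shown sits. Compound 3 `CN(c1cccc2c1CN(c1nc(Nc3cc(C(F)(F)F)cc(C(F)(F)F)c3)ncc1C(F)(F)F)C2)S(C)(=O)=O` also returns only a limit in this assay, > 30000 nM, and so it sits at the limit of > 30000 nM in this assay, at which 1 of the 3 values shown sits. Compound 3 therefore stands with no number of its own, and one further value among the three shown is likewise a limit, so only compound 1 carries a measured figure.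

Compound 4 `CN(c1cccc2c1CN(c1nc(Nc3cc(Cl)cc(C(F)(F)F)c3)ncc1C(F)(F)F)C2)S(C)(=O)=O` has not yet been measured. It differs from compound 3 in a single place: chloro in place of trifluoromethyl on an aromatic carbon. Within the data shown here, no pair of measured compounds differing in one place is available here, so the size of such a change cannot be read off from any neighbouring step. Since compound 3 gives only a limit in this assay, compound 4 is expected to stay at or near a limit as well, with no step beyond the usual scatter. Compound 4 is estimated at about 30000 nM in this assay, within a range of 8000 nM to 100000 nM. The estimated step of a number no higher from compound 3 to compound 4 (the limit leaves the size open) is expected to lie within the scatter.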

Compound 4, concentration for 50% growth inhibition: 21500 nM
For compound 4 the middle estimate is 1.4-fold (0.14 log units) above the measured one; low and high end bracket the measured number.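

In this assay compound 4, which carries chloro in place of trifluoromethyl on an aromatic carbon, gives a measured figure of 21500 nM, so this position now has a real number attached to it. The swap of this one group, four heavy atoms leaving and one entering, can be read only as a floor: an at least 1.3-fold lower number from compound 3 to compound 4 (0.14 log units; that floor lies within the scatter), so nothing shown places this change beyond the scatter. The true size of the step stays open because compound 3 has no number of its own, only a limit: the limit of > 30000 nM in this assay, at which 1 of the 4 values shown sits.

The compounds shown leave open how this aromatic carbon responds to groups other than these two, such as a nitrile, an amine or a carboxylic acid, and whether replacing the remaining trifluoromethyl on that ring would move the number at all. Steps to compound 1 and compound 2 cannot be read, since each differs from compound 3 and compound 4 in more than one place.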